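This account rests on a few compounds, and the source may have more. Where it says the series, first, only, none or still open, it means among the compounds named here.

In a functional assay on K562 cells (Homo sapiens) for antiproliferative activity, with a stated time of 72 h (a higher number here means a weaker inhibitor, a lower number a stronger inhibitor), three compounds that differ in one group on an aromatic carbon have been measured. Compound 1 `OC[C@H]1O[C@@H](n2cnc3c(NCc4ccccc4Cl)ncnc32)[C@H](O)[C@@H]1O` gives 64000 nM, compound 2 `OC[C@H]1O[C@@H](n2cnc3c(NCc4ccccc4Br)ncnc32)[C@H](O)[C@@H]1O` gives 10000 nM, and compound 3 `COc1ccccc1CNc1ncnc2c1ncn2[C@@H]1O[C@H](CO)[C@@H](O)[C@H]1O` gives 89000 nM. Compound 3 therefore sits level with compound 1, as a 1.4-fold higher number from compound 1 to compound 3 (0.14 log units; within the scatter) lies within the scatter, while an 8.9-fold higher number from compound 2 to compound 3 (0.95 log units; beyond the scatter) lies beyond it.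

The next change leads from compound 3 to compound 4 `OC[C@H]1O[C@@H](n2cnc3c(NCc4ccccc4OC(F)(F)F)ncnc32)[C@H](O)[C@@H]1O`: trifluoromethyl in place of methyl on an oxygen on an aromatic ring. Trifluoromethyl takes the place of methyl on an oxygen on an aromatic ring, so methoxy becomes trifluoromethoxy. Going by the values given here, no measured step covers this exact change, and the evidence is only indirect. The exchange of one group for another in this series has produced a 6.4-fold lower number from compound 1 to compound 2 (0.81 log units; beyond the scatter), which is modest, and the methoxy to chloro comparison shows no change beyond the scatter. Compound 2, at 10000 nM, marks the lowest number seen so far, and compound 3 marks the top of the measured span alongside compound 1. A modest step to a lower number is therefore expected, though a result level with compound 3 would not be surprising. The expected step is a 3.0-fold lower number from compound 3 to compound 4 (0.47 log units; beyond the scatter). Compound 4 is estimated at 30000 nM, with an expected range of 9000 nM to 90000 nM.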

Compound 4, half-maximal inhibitory concentration: 81400 nM
Estimate against measurement, compound 4: 2.7-fold (0.43 log units) below; measured number inside the range.
By their numbers in this assay, from the lowest: compound 2; then compounds 1, 4 and 3 (each within the scatter of the next).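

In this assay, trifluoromethyl in place of methyl on the oxygen gives a 1.1-fold lower number from compound 3 to compound 4 (0.04 log units; within the scatter), so this change, which turns methoxy into trifluoromethoxy, leaves the read-out level with compound 3. Compound 4 also stands level with the chloro compound 1, at a 1.3-fold higher number from compound 1 to compound 4 (0.10 log units; within the scatter), while an 8.1-fold higher number from compound 2 to compound 4 (0.91 log units; beyond the scatter) sets it apart from the bromo compound 2, so chloro, methoxy and trifluoromethoxy now form a level group of three, with compound 2 as the one exception. Nothing available on these compounds bears on why bromo stands apart from the other three groups or why the exchange on the oxygen leaves the number level.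

The compounds shown leave open whether iodo, an ethoxy chain or an amine on this aromatic carbon would match the lower number of compound 2 or join the level group of compounds 1, 3 and 4. They also leave open whether bromo would keep its separation from chloro, methoxy and trifluoromethoxy on a changed version of the shared core.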